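The compounds below may be only part of what the source reports. "The series", "measured", "known", "first", "only" and "open" are said of these compounds alone.

Compound 1 `Cc1noc(NS(=O)(=O)c2cccc3cc(N)ccc23)c1C` carries an amino group on its aromatic ring system, joined through a sulfonamide to a small heterocycle. In an assay on thoracic aorta for binding affinity to Endothelin-1 receptor (Rattus norvegicus) (a higher number here means a weaker inhibitor, a lower number a stronger inhibitor), compound 1 gives 2400 nM. Compound 2 `CC(=O)Nc1ccc2c(S(=O)(=O)Nc3onc(C)c3C)cccc2c1` differs from it by one change (acetyl in place of hydrogen on a nitrogen on an aromatic ring), and in this assay compound 2 gives 1300 nM, a change of a 1.8-fold lower number from compound 1 to compound 2 (0.27 log units; within the scatter). Compound 3 `Cc1noc(NS(=O)(=O)c2ccc3cc(N)ccc3c2)c1C` is built from the same atoms as compound 1 but joined differently, so that the amino group and the sulfonamide sit at other points of the ring system; the difference between the two cores is not broken down here. In this assay compound 3 gives 600 nM, the lowest of the three numbers. Compound 4 `CC(=O)Nc1ccc2cc(S(=O)(=O)Nc3onc(C)c3C)ccc2c1` is to compound 3 what compound 2 is to compound 1: the same change (acetyl in place of hydrogen on a nitrogen on an aromatic ring), at a place described in the same words. Among the measured compounds shown here, from the single earlier step of a 1.8-fold lower number from compound 1 to compound 2 (0.27 log units; within the scatter), which stayed within the scatter, a step of similar size is expected from compound 3 to compound 4 in this assay, namely a 1.5-fold lower number from compound 3 to compound 4 (0.18 log units; within the scatter). Compound 4 is therefore estimated at 400 nM.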

Compound 4, half-maximal inhibitory concentration: 3800 nM
Beside the measured number, compound 4's estimate is 9.5-fold (0.98 log units) below it; the measured number lies above the stated range.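

Putting acetyl in place of hydrogen on a nitrogen on an aromatic ring, the change that reads amino to acetamido, gives a 6.3-fold higher number from compound 3 to compound 4 (0.80 log units; beyond the scatter) in this assay. Set beside the earlier step, the same change does not carry over from one core to the other: the same change on two cores in this assay, a 1.8-fold lower number (0.27 log units; within the scatter) from compound 1 to compound 2 and a 6.3-fold higher number (0.80 log units; beyond the scatter) from compound 3 to compound 4, 12-fold (1.07 log units) apart, beyond the scatter of two such steps. This shows that in this series a step read on the core of compound 1 is no safe guide to the same step on the core of compound 3, though it does not show why the two cores differ, and two cores give no rule for what the change would do on a third.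

The compounds shown leave open whether a longer chain on that nitrogen, such as propanoyl in place of acetyl, would follow the pattern of compound 2 or that of compound 4 on each core. They also leave open how a carboxylic acid in place of the amino group would fare on these two cores.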